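Adding a Methoxy to the Dimethoxybenzyl Analogue

The source may hold more compounds than are shown below. What is called first, only, known or untested is meant among the compounds shown, and "the series" means these compounds.

Compound 1 `Nc1cc(N)c2nc(-c3ccccc3)c(Oc3ccc(Cl)c(Cl)c3)nc2c1` in a functional assay on NCI-H23 cells (Homo sapiens) for inhibition, read by sulforhodamine B assay, with a stated time of 48 h (a higher number here means that more compound is tolerated, a lower number that less compound is tolerated), gives only a limit, < 100000 nM.
Compound 2 `Nc1cc(N)c2nc(-c3ccccc3)c(NCc3ccc(Cl)c(Cl)c3)nc2c1` in this assay gives 55000 nM.
Compound 3 `COc1ccc(CNc2nc3cc(N)cc(N)c3nc2-c2ccccc2)cc1OC` in this assay gives 91200 nM.

Compound 3 holds the highest of the two numbers available; its nearest neighbour is compound 2, and the gap between them, a 1.7-fold higher number from compound 2 to compound 3 (0.22 log units; within the scatter), is within the scatter. The value of compound 1 is a limit of the assay and not a number, (the limit of < 100000 nM in this assay, at which 1 of the 3 values shown sits), so it cannot be ranked against the others.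

Compound 4 `COc1cc(CNc2nc3cc(N)cc(N)c3nc2-c2ccccc2)cc(OC)c1OC` differs from compound 3 by methoxy in place of hydrogen on an aromatic carbon. For the measured compounds named here, the only measured step, a 1.7-fold higher number from compound 2 to compound 3 (0.22 log units; within the scatter), exchanged one aryl group for another rather than adding a methoxy, so no measured step bears directly on this change. The expectation is therefore of no step beyond the scatter. Compound 4 is expected to give about 91000 nM, with a range from 45000 nM to 180000 nM. The expected step is a 1.0-fold lower number from compound 3 to compound 4 (0.00 log units; within the scatter). Since compound 3 already lies close to the limit seen for compound 1, a limit rather than a number is a real possibility for compound 4.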

Compound 4, concentration lethal to 50% of the cells: 33900 nM
For compound 4 the middle estimate is 2.7-fold (0.43 log units) above the measured one; the whole stated range lies above it.
By their numbers in this assay, from the lowest: compounds 4, 2 and 3 (each within the scatter of the next, the first and the last beyond it).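

In this assay, for the compounds shown here, (this assay), methoxy in place of hydrogen on an aromatic carbon, ortho to a methoxy group, gives the first step that lies beyond the scatter: a 2.7-fold lower number from compound 3 to compound 4 (0.43 log units; beyond the scatter). Going by these compounds alone, the only earlier step, a 1.7-fold higher number from compound 2 to compound 3 (0.22 log units; within the scatter), stayed within the scatter, so this position is the first place where a single change shifts the number, here towards less compound being tolerated. Nothing available here accounts for this shift.

On these data alone, it remains open whether a hydroxyl, a fluorine or an amine on the same aromatic carbon would shift the number in the same direction, or whether a longer chain in place of the methoxy would go further. Also open, as far as these compounds go, is whether the same added methoxy would have a comparable effect on the aryl group of compound 2.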